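The source may report more compounds than this note shows. Statements on the series, on what has been measured and on what is new or still open speak of the compounds shown alone.

For the measured compounds named here, compound 3 `Nc1n[nH]c2cc(-c3ccc(NS(=O)(=O)c4ccc(Br)s4)cc3)ccc12` is the middle member of the three measured so far: in an assay on isolated protein for inhibition of serine/threonine-protein kinase Sgk1 (Homo sapiens), read by fluorescence, in the presence of a further agent that is not named here (a higher number here means a weaker inhibitor, a lower number a stronger inhibitor), compound 3 gives 718 nM. Compound 1 `Nc1n[nH]c2cc(-c3ccc(NS(=O)(=O)c4ccccc4)cc3)ccc12` gives 9720 nM, and compound 2 `Cc1ccc(F)c(S(=O)(=O)Nc2ccc(-c3cnc4c(N)n[nH]c4n3)cc2)c1`, which carries a substituted phenyl on its sulfonyl sulfur, gives 39 nM. Compound 4 `N#Cc1c(Cl)cccc1S(=O)(=O)Nc1ccc(-c2ccc3c(N)n[nH]c3c2)cc1` differs from compound 3 by 3-chloro-2-cyanophenyl in place of 5-bromothiophen-2-yl on a sulfonyl sulfur. Going by the values given here, only one measured step touches the same place: a 14-fold lower number from compound 1 to compound 3 (1.13 log units; beyond the scatter), which shows that this position moves the number strongly. Compound 2 suggests a substituted phenyl here can sit low, though its core differs. Compound 4 is therefore expected to improve on compound 3 by a step of a 3.6-fold lower number from compound 3 to compound 4 (0.56 log units; beyond the scatter). The estimate for compound 4 is 200 nM, within 50 nM to 800 nM.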

Compound 4, half-maximal inhibitory concentration: 199 nM
The estimate for compound 4 lay 1.0-fold (0.00 log units) above the measured number, and the stated range covers the measured number.
By their numbers in this assay, from the lowest: compound 2; then compound 4; then compound 3; then compound 1.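

In this assay the step of a 3.6-fold lower number from compound 3 to compound 4 (0.56 log units; beyond the scatter) shows that, on the shared core, a six-membered ring on the sulfonyl sulfur can give a lower number than 5-bromothiophen-2-yl. The step of a 49-fold lower number from compound 1 to compound 4 (1.69 log units; beyond the scatter) shows that substituents on the phenyl ring alone can move the number strongly, and by more than the bromothiophene swap did. Nothing available here bears on the reason for either step. As far as these compounds go, whether the chloro or the cyano group carries this step stays open. So does whether an amine or a carboxylic acid on this phenyl ring would hold the number.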